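A few compounds are considered here, and "the series" means these few. Any claim that something is new, unique, unknown or untested is made for them only; others in the source may bear on it.

Measured so far:
compound 1, `O=C(CCCc1ccccc1)CC(=O)N[C@H]1CCOC1=O`
compound 2, `O=C(CCCCCCc1ccccc1)CC(=O)N[C@H]1CCOC1=O`
compound 3, `O=C(CCCCCCCc1ccccc1)CC(=O)N[C@H]1CCOC1=O`

In a functional assay on NCI-H630 cells (Homo sapiens) for cytotoxicity, read by sulforhodamine B assay, with a stated time of 5 days (on this read-out lower numbers stand for stronger inhibition and higher numbers for weaker inhibition), compound 3 gives 10000 nM and compound 2 gives 27000 nM. For compound 1 only a limit is recorded: in this assay compound 1 gives > 100000 nM, which is a limit of the assay and not a number. The step phenyl in place of benzyl on a saturated chain carbon, six bonds along the chain from a carbonyl carbon gives a 2.7-fold higher number from compound 3 to compound 2 (0.43 log units; beyond the scatter). The difference between the core of compound 1 and the core of compound 3 is not broken down here.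

Compound 4, `O=C(CCc1ccccc1)CC(=O)N[C@H]1CCOC1=O`, is not yet measured. It differs from compound 1 by phenyl in place of benzyl on a saturated chain carbon, two bonds along the chain from a carbonyl carbon. Within the data shown here, this is the same kind of change as the one from compound 3 to compound 2, but the place differs: there the phenyl enters six bonds along the chain from a carbonyl carbon, here two bonds along the chain from a carbonyl carbon. Compound 1 already sits at the limit (the limit of > 100000 nM in this assay, at which 1 of the 3 values shown sits), so compound 4 is expected to stay at or beyond that limit, with a step that the limit leaves unreadable from compound 1 to compound 4. Compound 4 is therefore estimated at 250000 nM, within 100000 nM to 1000000 nM.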

Compound 4, half-maximal inhibitory concentration: > 100000 nM
Compound 4: no number, only a limit; the forecaster's own chance of this, stated with the estimate: 85%; the middle value is on the limit's open side.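

In this assay, compound 1 and compound 4 are both recorded only as limits, not numbers, so no step between them can be read: the limit of > 100000 nM in this assay, at which 2 of the 4 values shown sit.

The compounds shown leave open whether phenyl in place of benzyl changes the read-out at all on a saturated chain carbon, two bonds along the chain from a carbonyl carbon.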